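This account rests on a few compounds, and the source may have more. Where it says the series, first, only, none or still open, it means among the compounds named here.

In a functional assay on LOX IMVI cells (Homo sapiens) for inhibition, read by sulforhodamine B assay, with a stated time of 48 h (a higher number here means a weaker inhibitor of growth, a lower number a stronger inhibitor of growth), compound 1 `O=C(Cc1csc2nc(-c3ccc(Br)cc3)cn12)N/N=C/c1ccccc1` gives 91200 nM, while compound 2 `O=C(Cc1csc2nc(-c3ccc(Br)cc3)cn12)N/N=C/c1ccccc1O` gives 12900 nM, the lower of the two numbers and so the stronger growth inhibitor of this pair. Compound 3 `O=C(Cc1csc2nc(-c3ccc(Br)cc3)cn12)N/N=C/c1ccc(O)cc1` differs from compound 2 in one place: 4-hydroxyphenyl in place of 2-hydroxyphenyl on a carbon with a double bond to nitrogen. Among the compounds with values here, only one measured step bears on this change: a 7.1-fold lower number from compound 1 to compound 2 (0.85 log units; beyond the scatter), a modest change that came with hydroxy in place of hydrogen on an aromatic carbon. Within the data shown here, that step shows that adding a hydroxy can change the number, but no measurement yet shows what moving it does. Compound 3 still carries a hydroxy, so it is expected to keep part of that gain. In this assay, the expected step of a 1.9-fold higher number from compound 2 to compound 3 (0.29 log units; within the scatter) is small, toward a higher number, and may not exceed the scatter. For compound 3 the estimated value is 25000 nM, with an expected range from 8000 nM to 70000 nM.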

Compound 3, concentration for total growth inhibition: 26300 nM
For compound 3 the middle estimate is 1.1-fold (0.02 log units) below the measured one; the range from low to high includes it.
By their numbers in this assay, from the lowest: compound 2; then compound 3; then compound 1.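

In this assay, moving the hydroxy around the ring gives a 2.0-fold higher number from compound 2 to compound 3 (0.31 log units; beyond the scatter), so with the same atoms joined differently, the place of the hydroxy matters and not only its presence. The gain is still there for the moved group, with a 3.5-fold lower number from compound 1 to compound 3 (0.54 log units; beyond the scatter), so both hydroxy-bearing rings give lower numbers than the ring without a hydroxy in compound 1, and 2-hydroxyphenyl gives the lowest of the three. No measurement at hand explains why the two placements differ.

As far as these compounds go, what 3-hydroxyphenyl would give remains open, so two placements cannot yet be read as a trend around the ring. From the compounds shown here alone, it is also open whether the hydroxy itself is needed, or whether a methoxy, an amine or a fluorine in its place would lower the number as well.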